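Swapping the oxazole for a pyrazine on the amide carbonyl

The source may report more compounds than this note shows. Statements on the series, on what has been measured and on what is new or still open speak of the compounds shown alone.

Values in an ADME assay on microsomes from liver (Rattus norvegicus, strain Crj;CD(SD)) for metabolic stability, read by LC-MS, using NADPH, with a stated time of 30 min, tested at 0.1 uM; a higher number here means that more of the compound is left, a lower number that less of the compound is left:
Compound 1 `Cc1cc(C#N)cnc1C(=O)Nc1ccc(F)c([C@]2(C)C=C(CF)OC(N)=N2)c1` gives 34%
Compound 2 `C[C@@]1(c2cc(NC(=O)c3coc(C(F)F)n3)ccc2F)C=C(CF)OC(N)=N1` gives 57%

Of the two numbers in hand, the higher belongs to compound 2, at 57%, and the gap to compound 1, at 34%, lies beyond the scatter. The unmeasured compound 3 `C[C@@]1(c2cc(NC(=O)c3cnc(C(F)F)cn3)ccc2F)C=C(CF)OC(N)=N1` keeps the shared core and differs from compound 2 in one place: 5-(difluoromethyl)pyrazin-2-yl in place of 2-(difluoromethyl)-1,3-oxazol-4-yl on a carbonyl carbon. In words, 5-(difluoromethyl)pyrazin-2-yl stands in place of 2-(difluoromethyl)-1,3-oxazol-4-yl on a carbonyl carbon.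

Within the data shown here, only one measured step bears on this place: a number 23 percentage points higher from compound 1 to compound 2 (beyond the scatter), a modest change beyond the scatter. A single step gives no rule for the new group. The entering group is six-membered, like the 5-cyano-3-methylpyridin-2-yl of compound 1 at 34%, but it keeps the difluoromethyl of compound 2. A fall smaller than the measured step is therefore expected, and the estimated step is a number 12 percentage points lower from compound 2 to compound 3 (beyond the scatter). For compound 3 the expected value is 45%, within an estimated range from 28% to 62%.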

Compound 3, percent of the compound remaining: 44%
The estimate for compound 3 lay 1 percentage points above the measured number, within the range that was stated.
By their numbers in this assay, from the lowest: compounds 1 and 3 (each within the scatter of the next); then compound 2.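

In this assay, the difluoromethyl group appears on both sides of the change from 2-(difluoromethyl)-1,3-oxazol-4-yl to 5-(difluoromethyl)pyrazin-2-yl, yet the result is a number 13 percentage points lower from compound 2 to compound 3 (beyond the scatter), so at this position on the carbonyl carbon that group alone does not preserve the number seen for compound 2. The comparison with the cyano-bearing group shows a number 10 percentage points higher from compound 1 to compound 3 (within the scatter), so 5-(difluoromethyl)pyrazin-2-yl and 5-cyano-3-methylpyridin-2-yl cannot be told apart here, although they differ in their ring atoms and substituents. Across these three compounds, the two with a six-membered aromatic ring, compound 1 and compound 3, lie within the scatter of each other, while compound 2, with its five-membered aromatic ring, stands apart from both, a pattern that none of the three goes against but that rests on a single five-membered example.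

From the compounds shown here alone, it remains open how a methoxy group in place of the difluoromethyl would read on either ring, and whether a thiazole ring on the carbonyl carbon would fall with compound 2 or with the other two. Nothing available accounts for the differences between these groups.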